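A few compounds are considered here, and "the series" means these few. Any claim that something is new, unique, unknown or untested is made for them only; others in the source may bear on it.

Series notes on a functional assay on SMMC-7721 cells (Homo sapiens) for antiproliferative activity, read by MTT assay, with a stated time of 72 h; on this read-out higher numbers stand for weaker inhibition and lower numbers for stronger inhibition:
- Compound 1 `Cc1nn(C)c(Oc2ccc(I)cc2)c1/C=N\CCCCCOc1cc2oc(=O)cc(C)c2cc1Cl` gives > 25000 nM in this assay, an assay limit and not a number.
- Compound 2 `Cc1ccc(Oc2c(/C=N\CCCCCOc3cc4oc(=O)cc(C)c4cc3Cl)c(C)nn2C)cc1` gives 11100 nM in this assay.
- Compound 3 `Cc1nn(C)c(Oc2ccc(F)cc2F)c1/C=N\CCCCCCOc1cc2oc(=O)cc(C)c2cc1Cl` gives > 25000 nM in this assay, again an assay limit.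

Compound 3 thus stands at the limit of > 25000 nM in this assay, at which 2 of the 3 values shown sit, with no number of its own. Compound 4 `Cc1nn(C)c(Oc2ccccc2Br)c1/C=N\CCCCCCOc1cc2oc(=O)cc(C)c2cc1Cl` differs from it by 2-bromophenyl in place of 2,4-difluorophenyl on an oxygen on an aromatic ring. Within the data shown here, the only measured step, an at least 2.2-fold lower number from compound 1 to compound 2 (0.35 log units; beyond the scatter), concerns another position and another exchange, so no measured step bears directly on the change from compound 3 to compound 4. No step beyond the scatter is therefore expected, and compound 4 is expected to stay near the limit. Compound 4 is estimated at 20000 nM, with a range from 8000 nM to 50000 nM. That estimate means an expected step of an at least 1.2-fold lower number from compound 3 to compound 4 (0.09 log units; that floor lies within the scatter).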

Compound 4, half-maximal inhibitory concentration: 19700 nM
Beside the measured number, compound 4's estimate is 1.0-fold (0.01 log units) above it; measured number inside the range.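

In this assay, 2-bromophenyl in place of 2,4-difluorophenyl on an oxygen on an aromatic ring gives an at least 1.2-fold lower number from compound 3 to compound 4 (0.10 log units; that floor lies within the scatter). Compound 4 gives 19700 nM, a measured number, so this exchange yields a reading at this position. Compound 3 has only an assay limit, so the true size of the step stays unknown: the limit of > 25000 nM in this assay, at which 2 of the 4 values shown sit.

Going by these compounds, whether a phenyl ring carrying an amine or a carboxylic acid in place of the halogens would move the number beyond the scatter remains open.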